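Compound 3 to compound 4: one fluoro fewer

The source may report more compounds than this note shows. Statements on the series, on what has been measured and on what is new or still open speak of the compounds shown alone.

In a physicochemical assay for solubility, at pH 7 (a lower number here means a less soluble compound, a higher number a more soluble compound), compound 1 (`CN1CCC(C(=O)N2Cc3c(NC(=O)C4CCC4)n[nH]c3C2(C)C)CC1`) gives > 225000 nM as a limit and not a number. Compound 2 (`CN1CCC(C(=O)N2Cc3c(NC(=O)c4ccc(Cl)cc4)n[nH]c3C2(C)C)CC1`) gives > 225000 nM as a limit too. Compound 3 (`CN1CCC(C(=O)N2Cc3c(NC(=O)c4ccc(F)c(F)c4)n[nH]c3C2(C)C)CC1`) gives > 225000 nM as a limit as well, so it has no number of its own (the limit of > 225000 nM in this assay, at which 3 of the 3 values shown sit). Compound 4 (`CN1CCC(C(=O)N2Cc3c(NC(=O)c4cccc(F)c4)n[nH]c3C2(C)C)CC1`) carries hydrogen in place of fluoro on an aromatic carbon of compound 3 (hydrogen in place of fluoro on an aromatic carbon). Within the data shown here, three measured steps bear on it (a step that the two limits leave unreadable from compound 1 to compound 2 and a step that the two limits leave unreadable from compound 1 to compound 3 and a step that the two limits leave unreadable from compound 2 to compound 3) and none has a readable size, so no step beyond the scatter and no direction is expected in this assay for compound 4. The estimated step (a step that the limit leaves unreadable from compound 3 to compound 4) stays within the scatter. Compound 4 is estimated at 240000 nM within a range of 150000 nM to 350000 nM and is expected to be reported as a limit again.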

Compound 4, solubility: > 225000 nM
Compound 4 gave a limit, no number (the forecaster's own chance of this, stated with the estimate: 85%); the middle value is on the limit's open side.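

Compound 4 sits at a limit in this assay, as do compound 1, compound 2 and compound 3, so no step among these four compounds can be read: the limit of > 225000 nM in this assay, at which 4 of the 4 values shown sit.

The compounds shown leave open whether the cyclobutyl, 4-chlorophenyl, 3,4-difluorophenyl and 3-fluorophenyl groups differ at all in this assay.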